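This account rests on a few compounds, and the source may have more. Where it says the series, first, only, none or still open, it means among the compounds named here.

Working notes on the series in an assay on CHO cells for displacement of a labelled ligand from Substance-P receptor (Homo sapiens); a higher number here means a weaker inhibitor, a lower number a stronger inhibitor.

Compound 1 is `O=C(NCc1cc(C(F)(F)F)cc(C(F)(F)F)c1)C(c1ccccc1)c1ccccc1` and in this assay compound 1 gives 526 nM. Compound 2 is `CN(Cc1cc(C(F)(F)F)cc(C(F)(F)F)c1)C(=O)C(c1ccccc1)c1ccccc1`; in this assay compound 2 gives 47 nM. The change from compound 1 to compound 2 is methyl in place of hydrogen on an amide-type nitrogen, and it made the step of an 11-fold lower number from compound 1 to compound 2 (1.05 log units; beyond the scatter).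

Compound 3 is `O=C(NCCCc1cc(C(F)(F)F)cc(C(F)(F)F)c1)C(c1ccccc1)c1ccccc1` and in this assay compound 3 gives 593 nM. The difference between the core of compound 3 and the core of compound 1 is not broken down here; the two values lie within the scatter of each other. Against compound 2, compound 3 stands at a number that is higher and beyond the scatter.

Compound 4, not yet measured, is `CN(CCCc1cc(C(F)(F)F)cc(C(F)(F)F)c1)C(=O)C(c1ccccc1)c1ccccc1`. From compound 3 to compound 4 the change is methyl in place of hydrogen on an amide-type nitrogen, the same change as from compound 1 to compound 2, with the place described in the same words. Within the data shown here, the step is expected to be an 11-fold lower number from compound 3 to compound 4 (1.03 log units; beyond the scatter), because an 11-fold lower number from compound 1 to compound 2 (1.05 log units; beyond the scatter) was seen once on the core of compound 1; only one such pair exists, so the transfer to the core of compound 3 is untested. Compound 4 is therefore expected near 55 nM, with a range estimated from 25 nM to 130 nM.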

Compound 4, half-maximal inhibitory concentration: 323 nM
Compound 4: middle estimate off by 5.9-fold (0.77 log units), on the low side, outside the stated range (above it).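

In this assay, methyl in place of hydrogen on an amide-type nitrogen does not keep the size of its first step on the core of compound 3, where the result is a 1.8-fold lower number from compound 3 to compound 4 (0.26 log units; within the scatter). The size of the step therefore depends on the core in this pair of cores, and the large step seen on the core of compound 1 cannot be read as a general value for this change: the same change on two cores in this assay, an 11-fold lower number (1.05 log units; beyond the scatter) from compound 1 to compound 2 and a 1.8-fold lower number (0.26 log units; within the scatter) from compound 3 to compound 4, 6.1-fold (0.79 log units) apart, beyond the scatter of two such steps. Two pairs do not show why the steps differ, and they do not show what size the step would take on any further core.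

Still open, going by these compounds, is how the same change behaves on a core with a longer chain leading to the ring. Also open, on these data alone, is whether ethyl in place of the methyl on the amide-type nitrogen gives a step closer to the large one or to the one within the scatter.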